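The Same Fluoro Step Made on Two Cores

The compounds below may be only part of what the source reports. "The series", "measured", "known", "first", "only" and "open" are said of these compounds alone.

This account concerns four compounds and one read-out, an assay on isolated protein for inhibition of RAC-alpha serine/threonine-protein kinase (Homo sapiens), tested at 30 uM; a lower number here means less inhibition, a higher number more inhibition at the concentration tested (going by the name of the read-out). Compound 1 has the structure `Cn1cnc2c(Nc3ccccc3)ncnc21`, and in this assay compound 1 gives 0%. Compound 2, with the structure `Cn1cnc2c(Nc3ccc(F)cc3)ncnc21`, differs from compound 1 by fluoro in place of hydrogen on an aromatic carbon. In this assay compound 2 gives 0%, so the step reads no change at the digits printed from compound 1 to compound 2 (within the scatter).

Compound 3 has the structure `c1ccc(C[n+]2c[nH]c3ncncc32)cc1` and carries a different core; the difference between the two cores is not broken down here. In this assay compound 3 gives 9%, a number that lies within the scatter of both compound 1 and compound 2, so no order among the three can be claimed.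

Compound 4, with the structure `Fc1ccc(C[n+]2c[nH]c3ncncc32)cc1`, is not yet measured. It differs from compound 3 by fluoro in place of hydrogen on an aromatic carbon, and this is the same change that turns compound 1 into compound 2: the entering group and the place are described in the same words for both pairs.

For compound 4 the expected step is a number 2 percentage points lower from compound 3 to compound 4 (within the scatter), because no change at the digits printed from compound 1 to compound 2 (within the scatter) was measured when the same change was made on the other core. The estimate for compound 4 in this assay is therefore 7%, expected to fall between 0% and 18%.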

Compound 4, a percentage reported as inhibition, at one concentration (the size of the read-out at that concentration, not a potency): 8%
The estimate for compound 4 lay 1 percentage points below the measured number; the measured number falls inside the stated range.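

In this assay, fluoro in place of hydrogen on an aromatic carbon gives a number 1 percentage points lower from compound 3 to compound 4 (within the scatter), while the same change on the core of compound 1 gives no change at the digits printed from compound 1 to compound 2 (within the scatter). Set side by side, the two steps agree, so in these two pairs the change reads the same on both cores: the same change on two cores in this assay, no change at the digits printed (within the scatter) from compound 1 to compound 2 and a number 1 percentage points lower (within the scatter) from compound 3 to compound 4, 1 percentage points apart, within the scatter of two such steps. This does not show that the change carries over in general, since it rests on two pairs only, each read at a single concentration, and all four compounds give small numbers, so neither pair tests whether the step would hold for a compound with a much larger read-out, and neither gives a potency.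

The compounds shown leave open whether a different group on the same aromatic carbon, such as an amine, a carboxylic acid or a longer chain, would give a step beyond the scatter on either core. They also leave open whether any such group would behave alike on the two cores, as fluoro does here, or whether its step would depend on the core that carries it.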